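The source may report more compounds than this note shows. Statements on the series, on what has been measured and on what is new or still open speak of the compounds shown alone.

Measured compounds in an assay on HEK293 cells for displacement of a labelled ligand from 5-hydroxytryptamine receptor 7 (Homo sapiens), read by scintillation counting, with a stated time of 30 min; a lower number here means a stronger inhibitor, a higher number a weaker inhibitor:
compound 1, `Oc1cccc(NCCCN2CCN(c3ccccc3)CC2)c1`, gives 10.1 nM;
compound 2, `COC(=O)c1cccc(NCCCN2CCN(c3ccccc3)CC2)c1`, gives 77.9 nM.

For the measured compounds named here, compound 2 stands at the higher of the two numbers measured so far; its only neighbour is compound 1, and the one measured step, a 7.7-fold higher number from compound 1 to compound 2 (0.89 log units; beyond the scatter), separates them. Compound 3, `OCc1cccc(NCCCN2CCN(c3ccccc3)CC2)c1`, is the next compound to be tested. It differs from compound 2 by hydroxymethyl in place of methoxycarbonyl on an aromatic carbon: hydroxymethyl in place of methoxycarbonyl, on an aromatic carbon of a six-membered aromatic ring of carbon only. In counted terms the change removes a group with two hydrogen-bond acceptors and no donor and brings in a group with one donor and one acceptor.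

Going by the values given here, the only step that bears on this is a 7.7-fold higher number from compound 1 to compound 2 (0.89 log units; beyond the scatter), where a donor-bearing hydroxy gave way to the methoxycarbonyl and the number rose by a modest amount. Returning a donor-bearing group points the other way, so compound 3 is expected to give a lower number than compound 2, by about a 3.5-fold lower number from compound 2 to compound 3 (0.55 log units; beyond the scatter), though not necessarily all the way back to compound 1. Compound 3 is therefore estimated at 22 nM, with a likely range of 7 nM to 65 nM in this assay.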

Compound 3, inhibition constant: 109 nM
Compound 3: the middle estimate sits 5.0-fold (0.70 log units) below what was measured; the whole stated range lies below it.
By their numbers in this assay, from the lowest: compound 1; then compounds 2 and 3 (each within the scatter of the next).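

In this assay, placing hydroxymethyl instead of methoxycarbonyl on this aromatic carbon gives a 1.4-fold higher number from compound 2 to compound 3 (0.15 log units; within the scatter), so the two groups cannot be told apart here, even though hydroxymethyl brings in a hydrogen-bond donor and methoxycarbonyl has none. Having a donor at this carbon is therefore not enough to match compound 1: hydroxymethyl in place of hydroxy gives an 11-fold higher number from compound 1 to compound 3 (1.03 log units; beyond the scatter), a large step for a change of this kind, and it leaves compound 1 with the lowest number of the three, clearly apart from both compound 2 and compound 3. Nothing available explains why hydroxy stands apart from the other two groups.

The compounds shown leave open whether the oxygen attached directly to the ring matters on its own, which a methoxy group at the same carbon would help to test, since it keeps that oxygen but lacks the hydroxy hydrogen. They also leave open how an amine, a carboxylic acid or a longer chain such as hydroxyethyl would behave on this carbon.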